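The source may hold more compounds than are shown below. What is called first, only, known or untested is meant among the compounds shown, and "the series" means these compounds.

Measured so far in an ADME assay on HepG2 2.2.15 cells (Homo sapiens) for cytotoxicity, read by MTT assay, with a stated time of 8 days; on this read-out higher numbers stand for lower toxicity in this test and lower numbers for higher toxicity in this test:
- Compound 1 `CC(=O)Nc1ccc(-c2nn(Cc3ccc(C#N)cc3)c(=O)c3ccccc23)c(F)n1`: > 100000 nM, a limit of the assay and not a number
- Compound 2 `CC(C)c1cc(-c2ccc(F)nc2F)nn(Cc2ccc(Cl)cc2)c1=O`: 56700 nM
- Compound 3 `CN(C)c1ccc(-c2nn(Cc3ccc(C#N)cc3)c(=O)c3ccccc23)c(F)n1`: 79200 nM

Compound 3, at 79200 nM, lies within the scatter of compound 2 at 56700 nM. Among the measured compounds shown here, these are the only two true numbers in this assay.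

Compound 4 `Cc1ccc(-c2nn(Cc3ccc(C#N)cc3)c(=O)c3ccccc23)c(F)n1` keeps the core of compound 3 and changes one group, next to the ring nitrogen: methyl in place of dimethylamino on an aromatic carbon.

For the measured compounds named here, the one measured step at this place, where dimethylamino replaced acetamido, is an at least 1.2-fold lower number from compound 1 to compound 3 (0.10 log units; that floor lies within the scatter). That is thin evidence, and it gives no reason to expect a clear move for methyl in place of dimethylamino.

The expected change in this assay is therefore none beyond the scatter, and the estimated step is a 1.0-fold higher number from compound 3 to compound 4 (0.00 log units; within the scatter). A report of only a limit, as for compound 1 at the limit of > 100000 nM in this assay, at which 1 of the 3 values shown sits, is also possible for compound 4.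

For compound 4 the estimate is 80000 nM, with an expected range from 40000 nM to 100000 nM.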

Compound 4, half-maximal cytotoxic concentration: > 100000 nM
Compound 4 ended at the assay's limit (the forecaster's own chance of this, stated with the estimate: 40%); at least 1.2-fold (0.09 log units) between middle value and limit.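

In this assay, putting methyl in place of dimethylamino on this aromatic carbon, next to the ring nitrogen, gives an at least 1.2-fold higher number from compound 3 to compound 4 (0.10 log units; that floor lies within the scatter), so the smaller group brings no sign of higher toxicity in this test at this place, although the floor of the step does not show a real gain. Compound 4 gives a limit of the assay and not a number, and it shares that limit with compound 1: the limit of > 100000 nM in this assay, at which 2 of the 4 values shown sit. The step between compound 1 and compound 4 cannot be read, as both values are limits.

Going by these compounds, how far the true value of compound 4 lies past that limit stays open, and with it the real size of the step from dimethylamino. Also open, on these data alone, is how a primary amine, a methoxy group or a longer chain would read at this place.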